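Swapping Chloro for Nitro on a Benzyl Thioether

The source may hold more compounds than are shown below. What is called first, only, known or untested is meant among the compounds shown, and "the series" means these compounds.

Measured so far in a functional assay on HeLa cells (Homo sapiens) for antiproliferative activity, read by MTT assay, with a stated time of 48 h; a higher number here means a weaker inhibitor, a lower number a stronger inhibitor:
compound 1 `Cc1ccccc1CSc1nnc(-c2ccc3c(c2)OCCO3)o1` gives 19000 nM
compound 2 `Clc1ccccc1CSc1nnc(-c2ccc3c(c2)OCCO3)o1` gives 36800 nM

Going by the values given here, of the two numbers measured in this assay, compound 2 stands at the weak end, but the only step joining them, a 1.9-fold higher number from compound 1 to compound 2 (0.29 log units; within the scatter), lies within the scatter, so the two compounds cannot be told apart on these data.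

Compound 3 `O=[N+]([O-])c1ccccc1CSc1nnc(-c2ccc3c(c2)OCCO3)o1` is the next compound in the series. It differs from compound 2 by nitro in place of chloro on an aromatic carbon. Among the compounds with values here, the one measured step, a 1.9-fold higher number from compound 1 to compound 2 (0.29 log units; within the scatter), exchanged groups at the same aromatic carbon and produced no change beyond the scatter; no measured step involves a nitro group, so there is no basis for predicting a shift in either direction. The step of a 1.1-fold lower number from compound 2 to compound 3 (0.02 log units; within the scatter) is therefore expected to stay within the scatter. Compound 3 is estimated to give 35000 nM in this assay, with a range from 12000 nM to 110000 nM.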

Compound 3, half-maximal inhibitory concentration: 32700 nM
For compound 3 the middle estimate is 1.1-fold (0.03 log units) above the measured one; measured number inside the range.
By their numbers in this assay, from the lowest: compounds 1, 3 and 2 (each within the scatter of the next).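

In this assay a nitro group now joins methyl and chloro on the same aromatic carbon, ortho to a large group, yet the three compounds still cannot be separated: a 1.1-fold lower number from compound 2 to compound 3 (0.05 log units; within the scatter) and a 1.7-fold higher number from compound 1 to compound 3 (0.24 log units; within the scatter) both lie within the scatter. The earlier step exchanged only single small groups, whereas this one shows that three heavy atoms with two hydrogen-bond acceptors can replace one chlorine here with no readable shift. No evidence at hand bears on this result.

As far as these compounds go, whether an amine or a carboxylic acid on this aromatic carbon would move the number beyond the scatter remains open. From the compounds shown here alone, it is also open whether any of these groups would read the same on another carbon of that ring.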